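The compounds below may be only part of what the source reports. "The series", "measured", "known", "first", "only" and "open" are said of these compounds alone.

Measured so far in a functional assay on DU-145 cells (Homo sapiens) for inhibition, read by trypan blue exclusion, with a stated time of 96 h; on this read-out lower numbers stand for stronger inhibition of growth and higher numbers for weaker inhibition of growth:
compound 1, `Cc1ccc(S/C(=C/c2c[nH]c3ccccc23)C(=O)c2ccc(Cl)cc2)cc1`: 10000 nM
compound 2, `Cc1ccsc1/C=C(/SCc1ccc(F)cc1)C(=O)c1ccc(Cl)cc1`: 50000 nM
compound 3, `O=C(/C(=C\c1c[nH]c2ccc(Br)cc12)SCc1ccc(F)cc1)c1ccc(Cl)cc1`: 50000 nM

Compound 3 and compound 2 stand level within the scatter, and together they carry the two highest numbers of the three; compound 1 sits a clear step lower. Among the compounds with values here, the one measured step, no change at the digits printed from compound 2 to compound 3 (within the scatter), swaps the whole aryl group on the chain carbon and so says nothing about the bromo by itself.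

Compound 4, `O=C(/C(=C\c1c[nH]c2ccccc12)SCc1ccc(F)cc1)c1ccc(Cl)cc1`, differs from compound 3 in one place: hydrogen in place of bromo on an aromatic carbon. Within the data shown here, no measured pair isolates this change. Compound 1 does carry the unsubstituted indole, but it also bears a different group on sulfur, so the gap between compound 1 and compound 3 cannot be split between the two differences; it only shows that an unsubstituted indole is compatible with the lower number seen for compound 1. Removing a single bromine with no ring, donor or acceptor involved is a small change, and the default expectation is a step of a 1.7-fold lower number from compound 3 to compound 4 (0.22 log units; within the scatter) that stays within, or only just beyond, the scatter, with any movement more likely toward a lower number than a higher one. Compound 4 is therefore estimated at 30000 nM, with a range from 10000 nM to 100000 nM.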

Compound 4, concentration for 50% growth inhibition: 1000 nM
Compound 4: middle estimate off by 30-fold (1.48 log units), on the high side; the whole stated range lies above it.
By their numbers in this assay, from the lowest: compound 4; then compound 1; then compounds 2 and 3 (each within the scatter of the next).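

Working notes on the indole series in this assay: the bromo is not the small change it appeared to be, since removing this one heavy atom from an aromatic carbon gives a large step (a 50-fold lower number from compound 3 to compound 4 (1.70 log units; beyond the scatter)). With 4-fluorobenzyl held on the sulfur, the aryl swap that looked flat when it led to 5-bromo-1H-indol-3-yl (no change at the digits printed from compound 2 to compound 3 (within the scatter)) gives a large step when it leads to 1H-indol-3-yl instead (a 50-fold lower number from compound 2 to compound 4 (1.70 log units; beyond the scatter)), so the effect of that swap depends on the bromo at this carbon. With the unsubstituted 1H-indol-3-yl held, the group on sulfur also matters, as 4-fluorobenzyl in place of 4-methylphenyl gives a further step beyond the scatter (a 10-fold lower number from compound 1 to compound 4 (1.00 log units; beyond the scatter)).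

Still open, from the compounds shown here alone, is whether the loss seen with bromo is specific to that group or would also appear with a methoxy or an amine on the same aromatic carbon, and whether a group on the sulfur such as a longer alkyl chain would keep the lower number of compound 4. The data shown offer no measurement that explains any of these steps.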